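A few compounds are considered here, and "the series" means these few. Any claim that something is new, unique, unknown or untested is made for them only; others in the source may bear on it.

Series notes, antiproliferative readout.

Of the compounds shown here, three carry numbers so far. Compound 1 `Cn1c(N2N=C(c3ccccc3)CC2c2ccc(Cl)cc2)nc(-c2ccccc2)c(C#N)c1=O` gives, in a functional assay on A549 cells (Homo sapiens) for antiproliferative activity, with a stated time of 72 h (a higher number here means a weaker inhibitor, a lower number a stronger inhibitor), 3250 nM. Compound 2 `COc1ccc(C2CC(c3ccccc3)=NN2c2nc(-c3ccccc3)c(C#N)c(=O)n2C)cc1` differs from compound 1 by methoxy in place of chloro on an aromatic carbon; in this assay compound 2 gives 1760 nM, and the step is a 1.8-fold lower number from compound 1 to compound 2 (0.27 log units; within the scatter). Compound 3 `Cn1c(N2N=C(c3ccccc3)CC2c2ccc(Cl)cc2)nc(-c2ccc(Cl)cc2)c(C#N)c1=O` gives in this assay 24700 nM, the highest number of the three, and its step from compound 1 is a 7.6-fold higher number from compound 1 to compound 3 (0.88 log units; beyond the scatter).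

Compound 4 `COc1ccc(C2CC(c3ccccc3)=NN2c2nc(-c3ccc(Cl)cc3)c(C#N)c(=O)n2C)cc1` has no number yet. It differs from compound 3 by methoxy in place of chloro on an aromatic carbon, the same change that separates compound 2 from compound 1; the two occurrences sit at places described in the same words, so this is the same change made on a second core. The two cores differ by chloro in place of hydrogen on an aromatic carbon, which is the step already measured between compound 1 and compound 3.

For the measured compounds named here, the step from compound 3 to compound 4 has only one guide. That guide is the step of a 1.8-fold lower number from compound 1 to compound 2 (0.27 log units; within the scatter), which stayed within the usual scatter. Going by the values given here, on that basis the expected step is a 1.8-fold lower number from compound 3 to compound 4 (0.25 log units; within the scatter), with the estimate kept near compound 3 because only one prior example of this change exists and because compound 3 gives 24700 nM on a core where no other swap has yet been tried. Compound 4 is therefore expected at about 14000 nM in this assay, with a plausible range from 5000 nM to 40000 nM.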

Compound 4, half-maximal inhibitory concentration: 23800 nM
Compound 4: middle estimate off by 1.7-fold (0.23 log units), on the low side, within the range that was stated.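

In this assay, methoxy in place of chloro gives a 1.0-fold lower number from compound 3 to compound 4 (0.02 log units; within the scatter), so this swap leaves no readable difference on the chlorinated core, and its two occurrences agree: the same change on two cores in this assay, a 1.8-fold lower number (0.27 log units; within the scatter) from compound 1 to compound 2 and a 1.0-fold lower number (0.02 log units; within the scatter) from compound 3 to compound 4, 1.8-fold (0.25 log units) apart, within the scatter of two such steps The chloro in place of hydrogen step, now seen a second time as a 14-fold higher number from compound 2 to compound 4 (1.13 log units; beyond the scatter), also carries from one core to the other, and across these four compounds the chloro on that second aromatic ring outweighs anything the methoxy swap does: the same change on two cores in this assay, a 7.6-fold higher number (0.88 log units; beyond the scatter) from compound 1 to compound 3 and a 14-fold higher number (1.13 log units; beyond the scatter) from compound 2 to compound 4, 1.8-fold (0.25 log units) apart, within the scatter of two such steps This shows that both changes behaved alike on the two cores shown, but it rests on a single pair of cores; since both methoxy steps lie within the scatter, it shows no effect of that swap on either core, and it gives no reason for the large effect of the added chloro.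

Still open, from the compounds shown here alone, is whether an amine or a carboxylic acid at the position of the chloro or methoxy would follow the same pattern, and whether fluoro or methyl in place of the added chloro would produce a step of similar size. Also open, going by these compounds, is whether either change carries over when the methyl on the ring nitrogen gives way to a longer chain.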